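Swapping a methoxy for a nitro on a liver cancer cell series

This account rests on a few compounds, and the source may have more. Where it says the series, first, only, none or still open, it means among the compounds named here.

Of the compounds shown here, two have been tested so far in a functional assay on Hep 3B2 cells (Homo sapiens) for inhibition, read by sulforhodamine B assay, with a stated time of 72 h; a higher number here means a weaker inhibitor, a lower number a stronger inhibitor. Compound 1 `CC(C)Cc1ccc(C(C)c2n[nH]c(=S)n2N)cc1` gives 13100 nM in this assay, and compound 2 `COc1ccc(C2=Nn3c(nnc3C(C)c3ccc(-c4ccccc4)c(F)c3)SC2)cc1` gives 3500 nM. Of these two numbers, compound 2 holds the lower one, and its gap to compound 1 lies beyond the usual scatter, so compound 2 is the stronger of the pair; the two differ in more than one place, so no single structural cause can be read from them.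

Compound 3 `CC(c1ccc(-c2ccccc2)c(F)c1)c1nnc2n1N=C(c1ccc([N+](=O)[O-])cc1)CS2` is the next compound and differs from compound 2 in one place only: nitro in place of methoxy on an aromatic carbon, which on the wider view reads 4-methoxyphenyl to 4-nitrophenyl. For the measured compounds named here, no measured pair shows this exchange, so no size of step is known. With nothing to go on beyond the two values, the step of a 1.2-fold lower number from compound 2 to compound 3 (0.07 log units; within the scatter) is expected to stay within the scatter, with no clear direction. Compound 3 is therefore estimated at 3000 nM in this assay, in a range from 1000 nM to 9000 nM.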

Compound 3, half-maximal inhibitory concentration: 2900 nM
For compound 3 the middle estimate is 1.0-fold (0.01 log units) above the measured one; the range from low to high includes it.
By their numbers in this assay, from the lowest: compounds 3 and 2 (each within the scatter of the next); then compound 1.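

In this assay, replacing the 4-methoxyphenyl of compound 2 with the 4-nitrophenyl of compound 3 gives a 1.2-fold lower number from compound 2 to compound 3 (0.08 log units; within the scatter), so the two compounds cannot be told apart on this measurement. For the compounds shown here, this is the first comparison here that changes only one place, and it shows that, on this aromatic carbon para to a large group, methoxy with its 2 heavy atoms and nitro with its 3 heavy atoms give matching results in these cells, even though the group's atoms and its count of hydrogen-bond acceptors both change. No measurement shown explains this match, so the result describes the outcome of the exchange but not what lies behind it.

On these data alone, only these two groups have been compared at this position, so it remains open whether an amine, a carboxylic acid, a longer chain such as butoxy, or plain hydrogen would also give a matching number. As far as these compounds go, it is also open whether the same exchange would give a similar result on a different core, such as that of compound 1, or in any other cell line.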